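A few compounds are considered here, and "the series" means these few. Any claim that something is new, unique, unknown or untested is made for them only; others in the source may bear on it.

Measured compounds: compound 1 `CN(C)c1ccc(C(=O)Nc2cccc(NC(=O)COc3ccc4c(c3)OCCC4=O)c2)cc1`, giving 85 nM; compound 2 `CCc1ccc(C(=O)Nc2cccc(NC(=O)COc3ccc4c(=O)ccoc4c3)c2)cc1`, giving 24 nM.

In an assay on isolated protein for inhibition of Rho-associated protein kinase 2 (Homo sapiens), read by scintillation counting, radiometric assay and 33P incorporation, with a stated time of 40 min, in the presence of a further agent that is not named here (on this read-out lower numbers stand for stronger inhibition and higher numbers for weaker inhibition), compound 2 shows the lowest of the two numbers, with compound 1 standing at a higher number, a gap beyond the usual scatter. Compound 3 `Nc1cccc(C(=O)Nc2cccc(NC(=O)COc3ccc4c(=O)ccoc4c3)c2)c1` has not yet been measured. The change from compound 2 is 3-aminophenyl in place of 4-ethylphenyl on a carbonyl carbon. For the measured compounds named here, no step between measured compounds bears on this change, so the expectation rests on compound 2 alone. A modest shift toward a higher number is expected, a 2.1-fold higher number from compound 2 to compound 3 (0.32 log units; beyond the scatter), though it could fall within the scatter. Compound 3 is estimated at 50 nM, within 15 nM to 180 nM.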

Compound 3, half-maximal inhibitory concentration: 58 nM
For compound 3 the middle estimate is 1.2-fold (0.06 log units) below the measured one; measured number inside the range.
By their numbers in this assay, from the lowest: compound 2; then compounds 3 and 1 (each within the scatter of the next).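

In this assay, for the compounds shown here, 3-aminophenyl in place of 4-ethylphenyl on a carbonyl carbon gives a 2.4-fold higher number from compound 2 to compound 3 (0.38 log units; beyond the scatter), the first reading at this position with the rest of the structure held constant. The step is modest, and it comes with a change from no hydrogen-bond donors or acceptors in the group to one of each. Nothing measured here accounts for the step. The change swaps both the substituent and its place on the ring, so the effect of each remains unseparated. A 4-aminophenyl or 3-ethylphenyl group on the same carbonyl carbon would tell them apart.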